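This account rests on a few compounds, and the source may have more. Where it says the series, first, only, none or still open, it means among the compounds named here.

Compound 3 `Cn1nccc1-c1cccc2c1CCC2c1ncc[nH]1` gives in a functional assay on CHO cells for agonist activity at Alpha-1D adrenergic receptor (Homo sapiens), read by FLIPR and calcium flux (on this read-out lower numbers stand for an effect already at smaller amounts and higher numbers for an effect only at larger amounts of compound), a reading of > 10000 nM, which is a limit of the assay and not a number. Compound 1 `Cn1ccc(-c2cccc3c2CCC3c2ncc[nH]2)n1` also stops at a limit, > 10000 nM. Compound 2 `COc1cccc2c1CCC2c1ncc[nH]1` likewise sits at a limit, > 10000 nM. All three readings rest at the limit of > 10000 nM in this assay, at which 3 of the 3 values shown sit, so the steps a step that the two limits leave unreadable from compound 1 to compound 2, a step that the two limits leave unreadable from compound 1 to compound 3 and a step that the two limits leave unreadable from compound 2 to compound 3 cannot be read in size or direction. Compound 4 `c1ccc2c(c1)CCC2c1ncc[nH]1` differs from compound 3 by hydrogen in place of 1-methyl-1H-pyrazol-5-yl on an aromatic carbon. With no readable step among the measured pairs, the change is expected to leave compound 4 near the same limit, meaning a step that the limit leaves unreadable from compound 3 to compound 4 of no clear size. Compound 4 is therefore estimated at 20000 nM, with a likely range from 5000 nM to 100000 nM.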

Compound 4, half-maximal effective concentration: > 10000 nM
Compound 4 gave a limit, no number; the forecaster's own chance of this, stated with the estimate: 85%; the middle value is on the limit's open side.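

No step from compound 4 to compound 1, compound 2 or compound 3 can be read in size or direction: the limit of > 10000 nM in this assay, at which 4 of the 4 values shown sit.

The compounds shown leave open whether any substituent at this aromatic carbon of the shared core gives a readable effect in this assay.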